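The source may report more compounds than this note shows. Statements on the series, on what has been measured and on what is new or still open speak of the compounds shown alone.

Measured so far:
Compound 1 `COc1cc2ccc(CCc3ccc4ccccc4c3)cc2cc1O`: 3590 nM
Compound 2 `COCCOc1cc(/C=C/c2ccc3ccccc3c2)ccc1OC`: > 5000 nM (a limit)

In a functional assay on HT-29 cells (Homo sapiens) for inhibition (a lower number here means a stronger inhibitor, a higher number a weaker inhibitor), compound 2 gives > 5000 nM, which is a limit of the assay and not a number. Compound 1 gives a true number, 3590 nM.

Compound 3 `COCCOc1cc(/C=C\c2ccc3ccccc3c2)ccc1OC` is built from the same parts as compound 2: the two compounds have the same atoms and bonds and differ only in configuration as drawn: 1 of 1 stereo elements differ; a double bond is drawn E in compound 2 and Z in compound 3. A double bond is drawn E in compound 2 and Z in compound 3, and nothing else differs.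

For the measured compounds named here, no measured pair shows what such a change does in this assay, so any forecast here is uncertain. The nearest true number is that of compound 1, at 3590 nM, and it serves as a rough guide. The expected change is an at least 5.0-fold lower number from compound 2 to compound 3 (0.69 log units; beyond the scatter), towards stronger inhibition. For compound 3 the estimated value is 1000 nM, with an expected range of 150 nM to 5000 nM.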

Compound 3, half-maximal inhibitory concentration: 2990 nM
Compound 3: middle estimate off by 3.0-fold (0.48 log units), on the low side; the measured number falls inside the stated range.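

In this assay compound 2 gives > 5000 nM, which is a limit of the assay and not a number. Switching the double bond from E to Z gives an at least 1.6-fold lower number from compound 2 to compound 3 (0.22 log units; that floor lies within the scatter), so this pair offers only a floor for the step and not its true size. Whatever shift lies behind that floor can be tied to the double bond alone, because nothing else in the pair changes: the fact that compounds 2 and 3 differ only in the configuration as drawn

From the compounds shown here alone, the true size of the step stays open, as does whether the same switch from E to Z would matter in any other compound. Also open, going by these compounds, is how the Z compound would behave in this assay if its side chain ended in an amine or a carboxylic acid.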